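A few compounds are considered here, and "the series" means these few. Any claim that something is new, unique, unknown or untested is made for them only; others in the source may bear on it.

Measured so far:
- compound 1, `C[C@H](NC(=O)c1cn(Cc2ccc(C(F)(F)F)cc2)nn1)c1ccc(C(=O)O)cc1`: > 10000 nM
- compound 2, `Cc1nnn(Cc2ccc(C(F)(F)F)cc2)c1C(=O)N[C@@H](C)c1ccc(C(=O)O)cc1`: > 10000 nM
- compound 3, `C[C@H](NC(=O)c1c(-c2ccccc2)nnn1Cc1ccccc1)c1ccc(C(=O)O)cc1`: 647 nM

In a functional assay on CHO cells for antagonist activity at prostaglandin E2 receptor EP4 subtype (Homo sapiens), read by calcium flux, with a stated time of 15 min (a lower number here means a stronger inhibitor, a higher number a weaker inhibitor), compound 1 gives > 10000 nM, which is a limit of the assay and not a number. Compound 2 likewise gives > 10000 nM, again a limit. Within the data shown here, compound 3 is the only member of the series with a numbered read-out, 647 nM; the other two values sit at the limit of > 10000 nM in this assay, at which 2 of the 3 values shown sit. Among the measured compounds shown here, no pair of measured compounds differs in a single place, so no measured step is available to calibrate the effect of any one change.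

Compound 4, `C[C@H](NC(=O)c1c(-c2ccccc2)nnn1CC1CCCCC1)c1ccc(C(=O)O)cc1`, has not yet been measured. Relative to compound 3 the change is cyclohexyl in place of phenyl on a saturated chain carbon bound to an aromatic nitrogen. For the measured compounds named here, no measured step bears on this exchange, and none of the measured compounds carries a cyclohexylmethyl group. The step of a 1.4-fold higher number from compound 3 to compound 4 (0.14 log units; within the scatter) is therefore expected to be small, of uncertain direction, and probably not beyond the scatter. On that basis compound 4 is estimated at 900 nM, within a range of 250 nM to 4000 nM.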

Compound 4, half-maximal inhibitory concentration: > 10000 nM
Compound 4 gave a limit, no number; the forecaster's own chance of this, stated with the estimate: 15%; middle value at least 11-fold (1.04 log units) away from the limit.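

In this assay, among these compounds, the change of phenyl to cyclohexyl on a saturated chain carbon bound to an aromatic nitrogen gives the first measured step: an at least 15-fold higher number from compound 3 to compound 4 (1.18 log units; beyond the scatter). The groups that leave and enter differ in whether the six-membered carbon ring is aromatic, so at this place the non-aromatic ring does not stand in for the aromatic one in this series. Compound 4 gives > 10000 nM, which is a limit and not a number, so the full size of the step stays unknown, and the series now rests on a single numbered value: the limit of > 10000 nM in this assay, at which 3 of the 4 values shown sit.

From the compounds shown here alone, whether a pyridylmethyl or phenethyl group at this place would keep or improve on compound 3 remains open. Compounds 1 and 2 differ from compound 3 in more than one place, so the contribution of each of their changes cannot be separated.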